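Replacing 5-chlorothiophen-2-yl with 1-acetylpiperidin-4-yl

The compounds below may be only part of what the source reports. "The series", "measured", "known", "first", "only" and "open" are said of these compounds alone.

Compound 1 `O=S(=O)(Nc1ccc(-c2nc3cc(NS(=O)(=O)c4ccccc4)ccc3o2)cc1)c1ccccc1` gives 13000 nM in a functional assay on HCT-116 cells (Homo sapiens) for cytotoxicity, read by resazurin assay, with a stated time of 48 h; a lower number here means that less compound is needed, a higher number that more compound is needed for the effect.
Compound 2 `COc1ccc(S(=O)(=O)Nc2ccc3oc(-c4ccc(NC(=O)c5ccc(Cl)s5)cc4)nc3c2)cc1` gives 5400 nM in this assay.
Compound 3 `COc1c(Br)cccc1C(=O)Nc1ccc(Sc2nc3ccccc3s2)cc1` gives 31000 nM in this assay.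

Of these three numbers, compound 2 has the lowest, and both gaps lie beyond the scatter: compound 1 sits higher, compound 3 higher still. Compound 4 `COc1ccc(S(=O)(=O)Nc2ccc3oc(-c4ccc(NC(=O)C5CCN(C(C)=O)CC5)cc4)nc3c2)cc1` has not been measured. It differs from compound 2 in one place: 1-acetylpiperidin-4-yl in place of 5-chlorothiophen-2-yl on a carbonyl carbon. Among the compounds with values here, no pair of measured compounds differs in only one place, so no measured step guides this change. The expected step is a 2.0-fold higher number from compound 2 to compound 4 (0.31 log units; beyond the scatter), a rise in the number that is modest but beyond the scatter. Compound 4 is therefore estimated at 11000 nM, with a range from 4000 nM to 30000 nM.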

Compound 4, half-maximal effective concentration: 15000 nM
Beside the measured number, compound 4's estimate is 1.4-fold (0.13 log units) below it; the measured number falls inside the stated range.
By their numbers in this assay, from the lowest: compound 2; then compounds 1 and 4 (each within the scatter of the next); then compound 3.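

In this assay, within the data shown here, putting 1-acetylpiperidin-4-yl in place of 5-chlorothiophen-2-yl on the carbonyl carbon gives a 2.8-fold higher number from compound 2 to compound 4 (0.44 log units; beyond the scatter), the only single-place step available here. This position therefore accepts a six-membered non-aromatic ring instead of a five-membered aromatic one, with only a modest rise in the number. No measurement here explains that rise.

From the compounds shown here alone, whether the chlorine, the sulfur or the aromatic ring matters most stays open. A plain phenyl or a piperidin-4-yl with a free amine on the same carbonyl carbon would help separate these.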